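The source may report more compounds than this note shows. Statements on the series, on what has been measured and on what is new or still open speak of the compounds shown alone.

Of the compounds shown here, two have been tested so far in a functional assay on HT-29 cells (Homo sapiens) for inhibition (a lower number here means a stronger inhibitor, a higher number a weaker inhibitor), and neither gave a number. Compound 1 (`C(=C\c1ccc2ccccc2c1)\c1ccoc1`) reads > 5000 nM, which is a limit of the assay and not a measured potency. Compound 2 (`COc1cc(/C=C/c2ccc3c(ccn3S(=O)(=O)c3ccccc3)c2)cc(OC)c1OC`) reads > 5000 nM, which is also a limit. The whole record in this assay is therefore (the limit of > 5000 nM in this assay, at which 2 of the 2 values shown sit), and it offers no ranking of the two compounds.

Compound 3 (`COc1cc(/C=C\c2ccc3c(ccn3S(=O)(=O)c3ccccc3)c2)cc(OC)c1OC`) is a close relative of compound 2: the two compounds have the same atoms and bonds and differ only in configuration as drawn: 1 of 1 stereo elements differ; a double bond is drawn E in compound 2 and Z in compound 3. The two compounds have the same atoms and bonds, and a double bond is drawn E in compound 2 and Z in compound 3. Among the measured compounds shown here, no measured pair here shows what such a switch does, so any forecast is uncertain. Compound 2 has a limit of > 5000 nM, so a change could only appear as a lower number, meaning a stronger inhibitor. A sizeable move in that direction is expected, although another limit reading remains possible. The estimated change is an at least 10-fold lower number from compound 2 to compound 3 (1.00 log units; beyond the scatter). Compound 3 is expected to give 500 nM, with an estimated range from 30 nM to 5000 nM.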

Compound 3, half-maximal inhibitory concentration: > 5000 nM
Compound 3: no number, only a limit; the forecaster's own chance of this, stated with the estimate: 30%; middle value at least 10-fold (1.00 log units) from the limit.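

Compound 3 gives a limit, not a number, so no step can be read between compound 2 and compound 3, which share one reading: the limit of > 5000 nM in this assay, at which 3 of the 3 values shown sit.

The compounds shown leave open how strongly any of them inhibits in this assay, and whether drawing the double bond E or Z changes that at all.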